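The compounds below may be only part of what the source reports. "The series", "measured", "known", "first", "only" and "open" are said of these compounds alone.

Working notes on the series, all in a functional assay on A549 cells (Homo sapiens) for inhibition, read by MTT assay, with a stated time of 72 h; a lower number here means a stronger inhibitor, a higher number a weaker inhibitor. Compound 1 (`Cc1ccc(NC(=O)C2CCN(C/C=C/c3ccccc3)CC2)cc1`) gives 29600 nM, compound 2 (`CC(C)c1ccc(NC(=O)C2CCN(C/C=C/c3ccccc3)CC2)cc1`) gives 9430 nM, and compound 3 (`O=C(Nc1ccc(F)c(Br)c1)C1CCN(C/C=C/c2ccccc2)CC1`) gives 11700 nM. Compound 3 stands second highest of these three numbers. Its neighbours are set by two steps: a 1.2-fold higher number from compound 2 to compound 3 (0.09 log units; within the scatter), and a 2.5-fold lower number from compound 1 to compound 3 (0.40 log units; beyond the scatter).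

Compound 4 (`O=C(NCc1ccccc1)C1CCN(C/C=C/c2ccccc2)CC1`) is the next case, with benzyl in place of 3-bromo-4-fluorophenyl on an amide-type nitrogen. Among the measured compounds shown here, no measured compound carries benzyl at that place, so no measured step transfers directly. The nearest guides are the changes on the aryl group of the amide, namely a 3.1-fold lower number from compound 1 to compound 2 (0.50 log units; beyond the scatter) and the step to the bromo-fluoro compound already given. Both are modest, and the whole set spans little.

A step of similar or smaller size is therefore expected, more likely towards a higher number and near the edge of the scatter. For the measured compounds named here, this direction is a weak call, resting on compound 1 at 29600 nM as the only measured compound with a higher number. For compound 4 the expected value is 22000 nM, with an estimated range of 10000 nM to 48000 nM. The estimate means a 1.9-fold higher number from compound 3 to compound 4 (0.27 log units; within the scatter).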

Compound 4, half-maximal inhibitory concentration: > 100000 nM
Compound 4 ended at the assay's limit (the forecaster's own chance of this, stated with the estimate: 12%); at least 4.5-fold (0.65 log units) between middle value and limit.
By their numbers in this assay, from the lowest: compounds 2 and 3 (each within the scatter of the next); then compound 1. At a limit, above all of these: compound 4.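

Compound 4 sits at a limit of this assay, not at a measured number, so its steps are lower bounds: the limit of > 100000 nM in this assay, at which 1 of the 4 values shown sits. Its steps are an at least 8.5-fold higher number from compound 3 to compound 4 (0.93 log units; beyond the scatter), an at least 10-fold higher number from compound 2 to compound 4 (1.02 log units; beyond the scatter) and an at least 3.3-fold higher number from compound 1 to compound 4 (0.52 log units; beyond the scatter), all beyond the scatter. The amide-type nitrogen is therefore more sensitive than the aryl changes alone suggested, as those gave only modest steps, a 3.1-fold lower number from compound 1 to compound 2 (0.50 log units; beyond the scatter) and a 2.5-fold lower number from compound 1 to compound 3 (0.40 log units; beyond the scatter), and among these four compounds only benzyl at this place reaches the limit, with no compound going against that.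

Compound 4 differs from the others both in the benzyl link and in carrying no substituent on its ring, and nothing shown separates the two: an unsubstituted phenyl and a 4-methylbenzyl on the amide-type nitrogen would tell them apart. On these data alone, the true size of the three new steps also stays open, as does the outcome with a longer chain such as 2-phenylethyl at this place.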